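Aryl Group Exchange on the Urea Nitrogen: An Expectation

The source may hold more compounds than are shown below. What is called first, only, known or untested is meant among the compounds shown, and "the series" means these compounds.

Of the compounds shown here, two of this set have been measured in a functional assay on HUVEC cells (Homo sapiens) for antiproliferative activity, read by MTT assay, with a stated time of 48 h; a lower number here means a stronger inhibitor, a higher number a weaker inhibitor. Compound 1 `O=C(Nc1cccc(C(F)(F)F)c1)Nc1nnc(Sc2ncnc3scc(-c4ccncc4)c23)s1` gives 22400 nM in this assay, and compound 2 `O=C(Nc1ccc(F)cc1)Nc1nnc(Sc2ncnc3scc(-c4ccncc4)c23)s1` gives 28300 nM. Among the compounds with values here, compound 2 carries the higher of the two numbers, with compound 1 as its only neighbour, and the single step between them, a 1.3-fold higher number from compound 1 to compound 2 (0.10 log units; within the scatter), stays within the scatter. Compound 3 `O=C(Nc1ccc(Cl)c(C(F)(F)F)c1)Nc1nnc(Sc2ncnc3scc(-c4ccncc4)c23)s1` remains unmeasured; it differs from compound 2 as follows: 4-chloro-3-(trifluoromethyl)phenyl in place of 4-fluorophenyl on an amide-type nitrogen. Within the data shown here, the only measured step that bears on this change is the earlier exchange of the aryl group on the same amide-type nitrogen, a 1.3-fold higher number from compound 1 to compound 2 (0.10 log units; within the scatter), which was too small to read as a real shift. Compound 3 is therefore expected to show a step of a 1.4-fold lower number from compound 2 to compound 3 (0.15 log units; within the scatter), not beyond the scatter. Compound 3 is estimated at 20000 nM in this assay, within a range from 8000 nM to 50000 nM.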

Compound 3, half-maximal inhibitory concentration: 18400 nM
Compound 3: middle estimate off by 1.1-fold (0.04 log units), on the high side, and the stated range covers the measured number.
By their numbers in this assay, from the lowest: compounds 3, 1 and 2 (each within the scatter of the next).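

In this assay, the 4-chloro-3-(trifluoromethyl)phenyl group on the amide-type nitrogen gives no step beyond the scatter against 4-fluorophenyl (a 1.5-fold lower number from compound 2 to compound 3 (0.19 log units; within the scatter)), and chloro in place of hydrogen on an aromatic carbon also stays within it (a 1.2-fold lower number from compound 1 to compound 3 (0.09 log units; within the scatter)). The position has now carried three differently substituted phenyl groups, and every step among compound 1, compound 2 and compound 3 lies within the scatter, so neither change can be read as a real shift. Nothing available explains these numbers.

From the compounds shown here alone, it remains open whether a group of another kind on this nitrogen, such as a straight alkyl chain or a phenyl ring bearing a carboxylic acid or an amine, would give a step beyond the scatter. Changes to the shared core also remain untested in the compounds shown.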